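Fluoro to trifluoromethyl on the fluorinated ring

The source may hold more compounds than are shown below. What is called first, only, known or untested is meant among the compounds shown, and "the series" means these compounds.

Measured so far:
compound 1 `Oc1cccc(-c2cc(-c3cccc(F)c3)cc(-c3cccc(O)c3)n2)c1` — 21300 nM
compound 2 `Oc1ccc(-c2cc(-c3cccc(F)c3)cc(-c3cccc(O)c3)n2)cc1` — 3510 nM

In a functional assay on T47D cells (Homo sapiens) for inhibition (a lower number here means a stronger inhibitor, a higher number a weaker inhibitor), compound 1 gives 21300 nM, the higher of the two numbers. Compound 2 gives 3510 nM in this assay. For the measured compounds named here, the single measured step, a 6.1-fold lower number from compound 1 to compound 2 (0.78 log units; beyond the scatter), changes the hydroxyphenyl and leaves the fluorinated ring untouched.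

Compound 3 `Oc1cccc(-c2cc(-c3cccc(C(F)(F)F)c3)cc(-c3cccc(O)c3)n2)c1` differs from compound 1 by trifluoromethyl in place of fluoro on an aromatic carbon. Going by the values given here, no measured step touches this position, so nothing here argues for a change beyond the scatter. Compound 3 is therefore expected near 21000 nM, within 6000 nM to 70000 nM. The expected step is a 1.0-fold lower number from compound 1 to compound 3 (0.01 log units; within the scatter).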

Compound 3, half-maximal inhibitory concentration: 4970 nM
Compound 3: middle estimate off by 4.2-fold (0.63 log units), on the high side, and the stated range ends above it.
By their numbers in this assay, from the lowest: compounds 2 and 3 (each within the scatter of the next); then compound 1.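

The position on the fluorinated ring is not silent: in this assay, trifluoromethyl in place of fluoro brings a 4.3-fold lower number from compound 1 to compound 3 (0.63 log units; beyond the scatter) and shows that the number responds to this position. The earlier step changed only the hydroxyphenyl, so it could not show this. No measurement here explains the shift.

As far as these compounds go, whether the same change carries over to the 4-hydroxyphenyl of compound 2 remains open. Also open, from the compounds shown here alone, is how an amine, a carboxylic acid or a longer chain would behave at this position.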